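Methyl for chloro on the shared core

The compounds below may be only part of what the source reports. "The series", "measured", "known", "first", "only" and "open" are said of these compounds alone.

In a functional assay on HCT-116 cells (Homo sapiens) for antiproliferative activity, read by CellTiter-Glo, with a stated time of 10 days (a lower number here means a stronger inhibitor, a higher number a weaker inhibitor), compound 1 `COCc1cc(-c2cnn(C)c2-c2sc3ccccc3c2C#N)cc2c(CN)n[nH]c(=O)c12` gives 19 nM and compound 2 `Cn1ncc(-c2cc(Cl)c3c(=O)[nH]nc(CN)c3c2)c1-c1sc2ccccc2c1C#N` gives 52 nM, so compound 2 holds the higher of the two numbers. Compound 3 `Cc1cc(-c2cnn(C)c2-c2sc3ccccc3c2C#N)cc2c(CN)n[nH]c(=O)c12` changes compound 2 by methyl in place of chloro on an aromatic carbon. Within the data shown here, the only measured change at this carbon, chloro in place of methoxymethyl, is modest: a 2.7-fold higher number from compound 1 to compound 2 (0.44 log units; beyond the scatter). Among the measured compounds shown here, no measured compound carries methyl alone for comparison, so a small move toward a lower number, possibly within the scatter, is expected: a 1.6-fold lower number from compound 2 to compound 3 (0.20 log units; within the scatter). For compound 3 the estimate is 33 nM, with an expected range from 13 nM to 85 nM.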

Compound 3, half-maximal inhibitory concentration: 30 nM
Beside the measured number, compound 3's estimate is 1.1-fold (0.04 log units) above it; the range from low to high includes it.
By their numbers in this assay, from the lowest: compounds 1, 3 and 2 (each within the scatter of the next, the first and the last beyond it).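

In this assay methyl on this aromatic carbon stays within the scatter of both earlier groups, chloro in a 1.7-fold lower number from compound 2 to compound 3 (0.24 log units; within the scatter) and methoxymethyl in a 1.6-fold higher number from compound 1 to compound 3 (0.20 log units; within the scatter). The exchange of chloro for methyl therefore gives no separable change here, and only the gap between methoxymethyl and chloro lies beyond the scatter. Nothing available explains these numbers. Still open, from the compounds shown here alone, is how an amine, a carboxylic acid or a longer chain on this carbon would compare with these three groups.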